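The source may report more compounds than this note shows. Statements on the series, on what has been measured and on what is new or still open speak of the compounds shown alone.

Working notes on the series. In a functional assay on MGC-803 cells (Homo sapiens) for cytotoxicity, read by MTT assay, with a stated time of 48 h (a lower number here means a stronger inhibitor, a higher number a weaker inhibitor), compound 1 `CC1=NN(C(=O)c2ccc([N+](=O)[O-])cc2)C(c2ccccc2O)C1` gives 50000 nM and compound 2 `CC1=NN(C(=O)CCl)C(c2cc(Br)ccc2O)C1` gives 13500 nM as its reading. Compound 3 `CC(=O)Oc1ccccc1C1CC(C)=NN1C(=O)CN(C(C)C)C(C)C` gives 20100 nM in the same test, which lies within the scatter of compound 2 and beyond the scatter of compound 1, whose number is the higher of that pair. Among the compounds with values here, no two measured compounds differ in one place only, so the series offers no measured step to lean on.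

The next compound is compound 4 `CC(=O)Oc1ccccc1C1CC(C)=NN1C(=O)CN1CCC(C(C)=O)CC1` with 4-acetylpiperidin-1-yl in place of diisopropylamino on a saturated chain carbon bound to a carbonyl carbon. In this assay no step beyond the scatter is expected, in either direction. The basis is thin: compound 2 at 13500 nM and compound 3 at 20100 nM stand within the scatter of each other while carrying different groups on that carbon. The estimated step of a 1.1-fold lower number from compound 3 to compound 4 (0.05 log units; within the scatter) is accordingly expected to stay within the scatter. In this assay the estimate for compound 4 is 18000 nM with an expected range from 7000 nM to 45000 nM as the likely span of a measurement.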

Compound 4, half-maximal inhibitory concentration: 4120 nM
Compound 4: middle estimate off by 4.4-fold (0.64 log units), on the high side; the whole stated range lies above it.
By their numbers in this assay, from the lowest: compound 4; then compounds 2 and 3 (each within the scatter of the next); then compound 1.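

In this assay, within the data shown here, the first step between compounds that differ in one place shows that the group on a saturated chain carbon bound to a carbonyl carbon can shift the reading beyond the scatter: 4-acetylpiperidin-1-yl in place of diisopropylamino gives a 4.9-fold lower number from compound 3 to compound 4 (0.69 log units; beyond the scatter) in this series. The earlier compounds shown here could not show this, as compound 2 and compound 3 differ in more than one place and their closeness says nothing about this position taken alone. No measurement in hand bears on the origin of this step, so its size stands as an observation only.

The compounds shown do not separate the part played by the six-membered ring of 4-acetylpiperidin-1-yl from that of its acetyl group, and piperidin-1-yl on the same carbon would be the direct comparison for that question. On these data alone, whether a morpholin-4-yl group, a primary amine or a carboxylic acid at this position would follow compound 4 or compound 3 also remains open, as does whether the step would carry over to a different core.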